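The source may hold more compounds than are shown below. What is called first, only, known or untested is meant among the compounds shown, and "the series" means these compounds.

Compound 3 `O=C(CCCCC1CCSS1)NCc1cn(CCCCOc2ccc3ccc(=O)oc3c2)nn1` gives 52.8% in a functional assay on PC-12 cells (Rattus norvegicus) for cytotoxicity, read by MTT assay, with stated times of 3 h and 2 h, tested at 5 uM (on this read-out lower numbers stand for a weaker effect and higher numbers for a stronger effect at the one concentration tested), the lowest of the three numbers shown, though compound 1 `O=C(CCCCC1CCSS1)NCc1cn(CCCOc2ccc3cc(C(=O)O)c(=O)oc3c2)nn1` with 57% and compound 2 `O=C(CCCCC1CCSS1)NCc1cn(CCCOc2ccc3cc(-c4ccc(Cl)cc4)c(=O)oc3c2)nn1` with 60.6% both lie within the scatter of it. Compound 4 `O=C(CCCCC1CCSS1)NCc1cn(CCCCOc2ccc3cc(-c4ccc(Cl)cc4)c(=O)oc3c2)nn1` differs from compound 3 by 4-chlorophenyl in place of hydrogen on an aromatic carbon. For the measured compounds named here, the one measured step that bears on this is a number 3.6 percentage points higher from compound 1 to compound 2 (within the scatter), where the same 4-chlorophenyl group enters the shared core, there in place of carboxy rather than hydrogen. On that basis the step to compound 4 is expected to stay within the scatter in this assay, with no direction beyond it. The expected step is a number 3.2 percentage points higher from compound 3 to compound 4 (within the scatter). Compound 4 is therefore estimated at 56%, between 44% and 68%.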

Compound 4, a percentage reported as activity, at one concentration (the size of the read-out at that concentration, not a potency): 52%
For compound 4 the middle estimate is 4 percentage points above the measured one, within the range that was stated.
By their numbers in this assay, from the lowest: compounds 4, 3, 1 and 2 (each within the scatter of the next).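

In this assay the step is a number 0.8 percentage points lower from compound 3 to compound 4 (within the scatter) when 4-chlorophenyl replaces hydrogen on the aromatic carbon two atoms from the ring oxygen. The earlier compounds shown here showed only its exchange for carboxy, as a number 3.6 percentage points higher from compound 1 to compound 2 (within the scatter) records, and this result adds that it also stays within the scatter against hydrogen itself. Nothing available explains this result. The compounds shown leave open whether an amine or a methoxy group on this carbon would move the number beyond the scatter.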